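Thiazole in place of fluorophenyl: cytotoxicity outlook

A few compounds are considered here, and "the series" means these few. Any claim that something is new, unique, unknown or untested is made for them only; others in the source may bear on it.

Compound 1 `CC(C)Cc1nn(-c2cccc(F)c2)cc1C(=O)NCc1ccc(F)cc1` was tested in a toxicity assay on HepG2 2.2.15 cells (Homo sapiens) for cytotoxicity, read by CCK-8 assay, with a stated time of 8 days; a higher number here means that more compound is tolerated, a lower number that less compound is tolerated. In this assay compound 1 reaches only the limit of the measurement, > 100000 nM, so no number is known for it. Compound 2 `CCOC(=O)c1cn(-c2ccc(F)cc2)nc1CC(C)C` likewise reaches only the limit, > 100000 nM. Compound 1 thus stands at the limit of > 100000 nM in this assay, at which 2 of the 2 values shown sit. Compound 3 `CC(C)Cc1nn(-c2nccs2)cc1C(=O)NCc1ccc(F)cc1` differs from compound 1 in one place: 1,3-thiazol-2-yl in place of 3-fluorophenyl on an aromatic nitrogen. Within the data shown here, no measured pair shows what such a change does in this assay. The step expected in this assay, a number no higher from compound 1 to compound 3 (the limit leaves the size open), is none beyond the scatter. Compound 3 is therefore expected to give 100000 nM, within 50000 nM to 200000 nM, most likely again as a limit.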

Compound 3, half-maximal cytotoxic concentration: > 100000 nM
Compound 3: a limit, no number (the forecaster's own chance of this, stated with the estimate: 85%); the middle value lies on the limit itself.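

Compound 1 and compound 3 both give only a limit, so no step between them can be read: the limit of > 100000 nM in this assay, at which 3 of the 3 values shown sit.

The compounds shown leave open at what concentration any of them harms the cells in this assay, and whether 1,3-thiazol-2-yl and 3-fluorophenyl differ there at all.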